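Pyrazole to methylisoxazole on the fused core

The source may hold more compounds than are shown below. What is called first, only, known or untested is meant among the compounds shown, and "the series" means these compounds.

Measured so far:
Compound 1 `c1cc(-c2ccn[nH]2)c2c(c1)C(c1ncc[nH]1)CC2`: 52 nM
Compound 2 `CS(=O)(=O)Nc1cccc2c1CCCC2c1ncc[nH]1`: 2150 nM; 142 nM; 234 nM (3 entries)

Compound 1 is the only one here with a single number in a functional assay on CHO cells for agonist activity at Alpha-1A adrenergic receptor (Homo sapiens), read by FLIPR and calcium flux; on this read-out lower numbers stand for an effect already at smaller amounts and higher numbers for an effect only at larger amounts of compound; one further entry for it gives no single number. Compound 2 carries a different core and spreads over several entries, (the several entries of compound 2 in this assay, 2150 nM; 142 nM; 234 nM (3 entries)).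

Compound 3 `Cc1oncc1-c1cccc2c1CCC2c1ncc[nH]1` differs from compound 1 by 5-methyl-1,2-oxazol-4-yl in place of 1H-pyrazol-5-yl on an aromatic carbon. For the measured compounds named here, no measured step of this kind is at hand. The loss of the hydrogen-bond donor is expected to weaken the effect in this assay by a step beyond the usual scatter, a 3.1-fold higher number from compound 1 to compound 3 (0.49 log units; beyond the scatter). Compound 3 is therefore estimated at 160 nM, between 40 nM and 650 nM.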

Compound 3, half-maximal effective concentration: 111 nM
Estimate against measurement, compound 3: 1.4-fold (0.16 log units) above, and the stated range covers the measured number.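

For the compounds shown here, this is the first step read at this aromatic carbon: in this assay, 5-methyl-1,2-oxazol-4-yl in place of 1H-pyrazol-5-yl gives a 2.1-fold higher number from compound 1 to compound 3 (0.33 log units; beyond the scatter). An effect remains with 0 hydrogen-bond donors in the entering group. The step is modest, and repeated entries of a single compound can lie far apart on this read-out: the several entries of compound 2 in this assay, 2150 nM; 142 nM; 234 nM (3 entries)

With one replacement shown, the share of the ring atoms and that of the methyl in this step stay open. Also open, as far as these compounds go, is how an amine or a carboxylic acid on this carbon would read.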